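The compounds below may be only part of what the source reports. "The series", "measured", "known", "first", "only" and "open" are said of these compounds alone.

Compound 1 `CCN(C)C(=O)/C=C1\CCc2c(F)cc(F)cc21`: 56 mg/kg
Compound 2 `O=C(/C=C1\CCc2ccccc21)NC1CC1`: 150 mg/kg
Compound 3 `O=C(/C=C1\CCc2ccc(F)cc21)NC1CCC1`: > 100 mg/kg

In a functional assay on the whole organism with Mus musculus as the target (a lower number here means that less compound is needed, a higher number that more compound is needed for the effect), compound 1, at 56 mg/kg, holds the lower of the two actual numbers, and the gap to compound 2, which gives 150 mg/kg, lies beyond the scatter. For compound 3, > 100 mg/kg is a limit and not a number.

Compound 4 `O=C(/C=C1\CCc2c(F)cc(F)cc21)NCCO` has (2-hydroxyethyl)amino in place of ethyl(methyl)amino on a carbonyl carbon. Within the data shown here, no measured pair shows this change, so the expectation rests on little. Compound 2, which also keeps an amide hydrogen, at 150 mg/kg suggests a move to a higher number in this assay, though its core differs. The expected change is a moderate rise, estimated as a 2.1-fold higher number from compound 1 to compound 4 (0.33 log units; beyond the scatter). For compound 4 the estimate is 120 mg/kg, with an expected range of 50 mg/kg to 300 mg/kg.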

Compound 4, dose for half-maximal effect: 100 mg/kg
Compound 4: the middle estimate sits 1.2-fold (0.08 log units) above what was measured, within the range that was stated.
By their numbers in this assay, from the lowest: compounds 1, 4 and 2 (each within the scatter of the next, the first and the last beyond it).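

Among these compounds, on the carbonyl carbon, (2-hydroxyethyl)amino in place of ethyl(methyl)amino gives the first one-place step, a 1.8-fold higher number from compound 1 to compound 4 (0.25 log units; within the scatter) in this assay. With the core of compound 1 kept, this exchange of groups of equal heavy-atom count does not separate the two compounds. Compound 3 carries a limit and not a number, so it enters no comparison here: the limit of > 100 mg/kg in this assay, at which 1 of the 4 values shown sits.

Open, as far as these compounds go, is what a carboxylic acid or an amine at the end of the chain would give in this assay. Also open, from the compounds shown here alone, is whether a longer chain ending in hydroxyl reads the same.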